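Series notes: ethyl to methyl on the amide-type nitrogen

This account rests on a few compounds, and the source may have more. Where it says the series, first, only, none or still open, it means among the compounds named here.

Measured so far, in this assay:
compound 1, `Nc1ccccc1NC(=O)c1ccc(CSC(=S)N2CCN(c3ccc(Cl)cc3)CC2)cc1`: 51.2%
compound 2, `Nc1ccccc1NC(=O)c1ccc(CSC(=S)N2CCN(C3CCCCC3)CC2)cc1`: 30.6%
compound 3, `CCN(Cc1ccncc1)C(=S)SCc1ccc(C(=O)Nc2ccccc2N)cc1`: 63.5%

All three were run in a functional assay on HeLa cells (Homo sapiens) for antiproliferative activity, read by CCK-8 assay, with a stated time of 72 h, tested at 2 uM; on this read-out higher numbers stand for a stronger effect at the one concentration tested and lower numbers for a weaker effect. Compound 3 stands highest of the three numbers; compound 1 is nearest to it and compound 2 furthest, and both of those gaps lie beyond the scatter. Within the data shown here, the only step between compounds that differ in one place is a number 20.6 percentage points lower from compound 1 to compound 2 (beyond the scatter), a modest fall on swapping a ring substituent of the amine nitrogen in the ring.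

Compound 4, `CN(Cc1ccncc1)C(=S)SCc1ccc(C(=O)Nc2ccccc2N)cc1`, is not yet measured. It differs from compound 3 as follows: hydrogen in place of methyl on a saturated chain carbon bound to an amide-type nitrogen

Among the measured compounds shown here, no measured step concerns an ethyl to methyl exchange, and the one step available sits at a different nitrogen and removes a ring rather than one carbon from a short chain. It therefore bears on this change only in a general sense, as a sign that substitution at the amine end can move the read-out by a modest amount. With a single carbon lost and no donor or acceptor changing, no step beyond the scatter is expected here. Compound 4 is expected to give about 58%, with a range from 42% to 72%. The step this estimate implies is a number 5.5 percentage points lower from compound 3 to compound 4 (within the scatter), expected to remain within the usual scatter.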

Compound 4, a percentage reported as inhibition, at one concentration (the size of the read-out at that concentration, not a potency): 29.5%
Compound 4: middle estimate off by 28.5 percentage points, on the high side; the whole stated range lies above it.
By their numbers in this assay, from the lowest: compounds 4 and 2 (each within the scatter of the next); then compound 1; then compound 3.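

In this assay, the exchange of ethyl to methyl on the nitrogen of the ethyl((pyridin-4-yl)methyl)amino group gives a number 34 percentage points lower from compound 3 to compound 4 (beyond the scatter), so this position responds strongly to the loss of one carbon, even though the change adds or removes no ring, donor, acceptor or charge. This single-carbon step is numerically larger than the ring-substituent exchange in a number 20.6 percentage points lower from compound 1 to compound 2 (beyond the scatter), so the size of a change at the amine end does not indicate the size of its effect in these two pairs. Nothing available explains the step, and no supporting measurement bears on it.

On these data alone, a single pair cannot define a trend in chain length, so the read-out of a propyl group, a longer chain or a bare hydrogen on this nitrogen remains open. As far as these compounds go, it is also open whether ethyl to methyl would give a step of similar size if a benzyl group replaced the (pyridin-4-yl)methyl group on the same nitrogen.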